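Trifluoromethyl in place of cyano on compound 3

The source may hold more compounds than are shown below. What is called first, only, known or untested is meant among the compounds shown, and "the series" means these compounds.

In a functional assay on MDA-MB-231 cells (Homo sapiens) for antiproliferative activity, read by MTT assay, with a stated time of 24 h (a lower number here means a stronger inhibitor, a higher number a weaker inhibitor), compound 3 (`N#Cc1ccc(S(=O)(=O)NC(CC(=O)O)c2ccccc2F)cc1`) gives 69700 nM. Compound 1 (`O=C(O)CC(NS(=O)(=O)c1ccc(C(F)(F)F)cc1)c1ccccc1`) gives 56100 nM, a value within the scatter of that of compound 3. Compound 2 (`O=C(O)CC(NS(=O)(=O)c1ccccc1)c1ccccc1F`) stands at > 100000 nM, which is a limit of the assay and not a number.

Compound 4 (`O=C(O)CC(NS(=O)(=O)c1ccc(C(F)(F)F)cc1)c1ccccc1F`) keeps the core of compound 3 and puts trifluoromethyl in place of cyano on an aromatic carbon.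

Among the measured compounds shown here, the one measured step that bears on this position is an at least 1.4-fold lower number from compound 2 to compound 3 (0.15 log units; that floor lies within the scatter), with cyano in place of hydrogen on an aromatic carbon. It starts from the limit of > 100000 nM in this assay, at which 1 of the 3 values shown sits, so it gives a floor and no full size, and it does not involve trifluoromethyl. The nearer guide is compound 1, which carries trifluoromethyl and gives 56100 nM, so no step beyond the scatter is expected in this assay, in either direction.

The expected step is a 1.2-fold lower number from compound 3 to compound 4 (0.07 log units; within the scatter), and this estimate stays within the scatter. For compound 4 the estimated value is 60000 nM, with an expected range from 33000 nM to 100000 nM.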

Compound 4, half-maximal inhibitory concentration: 47100 nM
For compound 4 the middle estimate is 1.3-fold (0.11 log units) above the measured one, within the range that was stated.
By their numbers in this assay, from the lowest: compounds 4, 1 and 3 (each within the scatter of the next). At a limit, above all of these: compound 2.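

In this assay, the exchange at this aromatic carbon and the neighbouring structural change both stay small: trifluoromethyl in place of cyano gives a 1.5-fold lower number from compound 3 to compound 4 (0.17 log units; within the scatter), and the addition of fluoro, with trifluoromethyl already present, gives a 1.2-fold lower number from compound 1 to compound 4 (0.08 log units; within the scatter). Set against hydrogen, however, trifluoromethyl gives the first step at this position that passes the scatter, an at least 2.1-fold lower number from compound 2 to compound 4 (0.32 log units; beyond the scatter), whereas cyano in place of hydrogen gives an at least 1.4-fold lower number from compound 2 to compound 3 (0.15 log units; that floor lies within the scatter), whose floor stays within it. That size is only a floor, as compound 2 stands at a limit of the assay and not at a number: the limit of > 100000 nM in this assay, at which 1 of the 4 values shown sits.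

On these data alone, only hydrogen, cyano and trifluoromethyl are seen on this carbon, so it remains open whether a methoxy group or an amine there would move the number beyond the scatter from compound 3 or compound 4. Also open, as far as these compounds go, is whether an amide in place of the carboxylic acid of the shared core would change the number at all in this assay.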